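Aryl variation on the oxadiazole: compound 3 to compound 4

The source may report more compounds than this note shows. Statements on the series, on what has been measured and on what is new or still open speak of the compounds shown alone.

Measured so far:
In a functional assay on the whole organism for inhibition, with Mythimna separata as the target, with a stated time of 5 days (a lower number here means that less compound is needed, a higher number that more compound is needed for the effect), compound 1 `Cc1ccc(-c2nnc(COc3cnn(C(C)(C)C)c(=O)c3Cl)o2)cc1` gives 19.9 ug/mL.
Compound 3 `CC(C)(C)n1ncc(OCc2nnc(-c3cc(F)c(F)cc3F)o2)c(Cl)c1=O` gives 75.7 ug/mL.
Compound 2 `Cc1cc(C)cc(-c2nnc(COc3cnn(C(C)(C)C)c(=O)c3Cl)o2)c1` reaches only the limit of > 300 ug/mL in this assay.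

Compound 3 stands highest of the two numbers given; the nearest is compound 1, and the gap is a 3.8-fold higher number from compound 1 to compound 3 (0.58 log units; beyond the scatter). Compound 4 `CC(C)(C)n1ncc(OCc2nnc(-c3ccc(Cl)cc3)o2)c(Cl)c1=O` differs from compound 3 by 4-chlorophenyl in place of 2,4,5-trifluorophenyl on an aromatic carbon. Within the data shown here, two measured steps bear on this: a 3.8-fold higher number from compound 1 to compound 3 (0.58 log units; beyond the scatter) shows the trifluorophenyl above the singly substituted 4-methylphenyl, while an at least 3.9-fold lower number from compound 2 to compound 3 (0.59 log units; beyond the scatter) shows it below the 3,5-dimethylphenyl. The 4-chlorophenyl, like the 4-methylphenyl, carries a single substituent, so the change from compound 3 is expected to reverse the first step, giving a modest lower number, a 2.5-fold lower number from compound 3 to compound 4 (0.40 log units; beyond the scatter). Compound 4 is therefore expected to give 30 ug/mL, within 10 ug/mL to 120 ug/mL.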

Compound 4, half-maximal effective concentration: 1.9 ug/mL
Compound 4: middle estimate off by 16-fold (1.20 log units), on the high side; the measured number lies below the stated range.
By their numbers in this assay, from the lowest: compound 4; then compound 1; then compound 3. At a limit, above all of these: compound 2.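

In this assay, the para-free comparison of the two singly substituted aryls is no longer neutral: chloro and methyl on the same phenyl are far apart, with a 10-fold lower number from compound 1 to compound 4 (1.02 log units; beyond the scatter), so a single substituent alone does not set the number at this position. The 4-chlorophenyl also sits well under the 2,4,5-trifluorophenyl, with a 40-fold lower number from compound 3 to compound 4 (1.60 log units; beyond the scatter), so more halogen on the phenyl does not go with a lower number in this pair. Against the 3,5-dimethylphenyl, which holds a limit and not a number, an at least 150-fold lower number from compound 2 to compound 4 (2.19 log units; beyond the scatter) is only a bound: the limit of > 300 ug/mL in this assay, at which 1 of the 4 values shown sits.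

On these data alone, whether the low number is particular to chloro stays open. A 4-bromophenyl or a 4-methoxyphenyl on the same core would test that.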